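Thiourea series: cytotoxicity tolerance and a furan-for-carboxy swap

The source may hold more compounds than are shown below. What is called first, only, known or untested is meant among the compounds shown, and "the series" means these compounds.

Measured so far:
Compound 1 `NC(=S)Nc1cccc(OCc2ccccc2)c1` gives > 50000 nM in an ADME assay on Ava5 cells (Homo sapiens) for cytotoxicity; a higher number here means that more compound is tolerated, a lower number that less compound is tolerated; this is a limit of the assay, not a number.
Compound 2 `NC(=S)Nc1cccc(OCCCCCOc2ccc(C(=O)O)cc2)c1` gives > 50000 nM in this assay; this too is a limit of the assay.

Compound 2 therefore has no numerical position in this assay; its reading sits at the limit of > 50000 nM in this assay, at which 2 of the 2 values shown sit, and the same holds for compound 1. Among the compounds with values here, no step between measured compounds can be drawn, so nothing in this set shows a change in tolerated concentration.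

Compound 3 `NC(=S)Nc1cccc(OCCCCCOc2ccc(-c3ccco3)cc2)c1` is the next compound to be tested in this assay. Relative to compound 2 the change is furan-2-yl in place of carboxy on an aromatic carbon, para to a large group.

With both measured compounds at the limit, no direction for the step can be read from the data. The expectation for compound 3 is that this assay again reports a limit, with a number no higher from compound 2 to compound 3 (the limit leaves the size open) as the estimated step, no change beyond the scatter. Compound 3 is thus estimated at 50000 nM, within 20000 nM to 100000 nM.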

Compound 3, half-maximal cytotoxic concentration: 11000 nM
Beside the measured number, compound 3's estimate is 4.5-fold (0.66 log units) above it; measured number below the stated range.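

In this assay the swap gives an at least 4.5-fold lower number from compound 2 to compound 3 (0.65 log units; beyond the scatter), so the substituent at this aromatic carbon, para to a large group, can change how much compound is tolerated: less is tolerated with furan-2-yl there than with carboxy. Within the data shown here, this is the first change in the set to produce a readable difference, and it shows that the shared thiourea-bearing core with its long chain does not by itself keep the reading at the limit. Compound 3 is also the only compound with a numerical reading, so the step has a floor but no upper bound, the other two readings being limits of the assay: the limit of > 50000 nM in this assay, at which 2 of the 3 values shown sit.

Among these compounds, the single swap removes carboxy and introduces furan-2-yl together, so these compounds cannot separate the loss of the one from the gain of the other; a phenyl, an amine or a plain hydrogen at the same carbon would bear on that question. From the compounds shown here alone, how a shorter or longer chain would read with furan-2-yl kept in place also stays open, and whether the lower number reflects anything specific to the furan ring cannot be told from one pair.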